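The source may report more compounds than this note shows. Statements on the series, on what has been measured and on what is new or still open speak of the compounds shown alone.

Measured in a physicochemical assay for solubility, with a stated time of 18 h, at pH 7.4; on this read-out higher numbers stand for higher solubility and lower numbers for lower solubility:
- compound 1 `COc1cccc(CNCCCNc2ccnc3cc(Oc4ccc(F)cc4)ccc23)c1O`: 14500 nM
- compound 2 `COc1cccc(CNCCCNc2ccnc3cc(-c4ccc(F)cc4)ccc23)c1O`: 32000 nM
- compound 3 `COc1cccc(CNCCCNc2ccnc3cc(Cc4ccc(F)cc4Cl)ccc23)c1O`: 4200 nM

Compound 3 sits lowest of the three numbers in this assay: a 3.5-fold lower number from compound 1 to compound 3 (0.54 log units; beyond the scatter) and a 7.6-fold lower number from compound 2 to compound 3 (0.88 log units; beyond the scatter). Compound 4 `COc1cccc(CNCCCNc2ccnc3cc(Cc4cc(C)cc(C)c4)ccc23)c1O` differs from compound 3 at the benzyl group only: 3,5-dimethylphenyl in place of 2-chloro-4-fluorophenyl on a saturated chain carbon bound to an aromatic carbon. For the measured compounds named here, no measured step alters the substitution pattern on that ring; the two steps that introduce the 2-chloro-4-fluorobenzyl group concern the connection to the shared core, not what sits on the ring. Going by the values given here, there is thus no direct precedent, and the step of a 1.3-fold lower number from compound 3 to compound 4 (0.12 log units; within the scatter) is expected to lie within the scatter or, at most, to be a modest move. Compound 4 is estimated at 3200 nM, with a range of 1100 nM to 9500 nM.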

Compound 4, solubility: 4200 nM
Estimate against measurement, compound 4: 1.3-fold (0.12 log units) below; measured number inside the range.
By their numbers in this assay, from the lowest: compounds 3 and 4 (each within the scatter of the next); then compound 1; then compound 2.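

In this assay, for the compounds shown here, the ring of the benzyl group changes for the first time: 3,5-dimethylphenyl in place of 2-chloro-4-fluorophenyl gives no change at the digits printed from compound 3 to compound 4 (within the scatter). The gaps to the other two compounds remain, with a 7.6-fold lower number from compound 2 to compound 4 (0.88 log units; beyond the scatter) and a 3.5-fold lower number from compound 1 to compound 4 (0.54 log units; beyond the scatter), so in these four compounds the two ring patterns on the benzyl group give matching numbers. No evidence on the cause of this is available.

As far as these compounds go, whether an amine or a carboxylic acid on the benzyl ring would shift the number stays open. So does the effect of a longer chain between that ring and the shared core.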